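Swapping benzyl for phenyl on the ether oxygen

The compounds below may be only part of what the source reports. "The series", "measured", "known", "first", "only" and "open" are said of these compounds alone.

Measured compounds:
- compound 1 `FC(F)(F)Oc1ccc(Oc2ccnc(N3CCC(NC(=S)Nc4cccnc4)CC3)c2Cl)cc1`: 25 nM
- compound 2 `N#Cc1c(Oc2ccc(OC(F)(F)F)cc2)ccnc1N1CCC(NC(=S)Nc2cccnc2)CC1`: 180 nM
- compound 3 `S=C(Nc1cccnc1)NC1CCN(c2cc(OCc3ccccc3)ccn2)CC1`: 2800 nM

In an assay on membranes from brain for binding affinity to Lysophosphatidylserine lipase ABHD12 (Mus musculus), read by fluorescence, with a stated time of 20 min (a lower number here means a stronger inhibitor, a higher number a weaker inhibitor), compound 3 gives the highest of the three numbers, so it is the weakest inhibitor shown. Compound 2, with 180 nM, sits nearest to it, and compound 1, with 25 nM, is furthest away.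

Compound 4 `S=C(Nc1cccnc1)NC1CCN(c2cc(Oc3ccccc3)ccn2)CC1` differs from compound 3 in one place: phenyl in place of benzyl on an oxygen on an aromatic ring. For the measured compounds named here, no measured pair shows this same change. Going by the values given here, the only measured step, a 7.2-fold higher number from compound 1 to compound 2 (0.86 log units; beyond the scatter), concerns a different position and does not bear on it. Compounds 1 and 2 do carry a phenoxy-type group, but they differ from compound 3 in more than one place, so their values only show that such compounds gave the lower numbers here. On that slim basis a lower number than for compound 3 is expected for compound 4, but with wide uncertainty. Compound 4 is estimated at 900 nM, within 200 nM to 4000 nM, which would be a step of a 3.1-fold lower number from compound 3 to compound 4 (0.49 log units; beyond the scatter).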

Compound 4, half-maximal inhibitory concentration: 1900 nM
Beside the measured number, compound 4's estimate is 2.1-fold (0.32 log units) below it; the range from low to high includes it.
By their numbers in this assay, from the lowest: compound 1; then compound 2; then compounds 4 and 3 (each within the scatter of the next).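

In this assay, replacing benzyloxy with phenoxy on the aromatic ring gives a 1.5-fold lower number from compound 3 to compound 4 (0.17 log units; within the scatter). For the compounds shown here, this is the first direct reading of this swap, and with nothing else changed, the two compounds cannot be told apart in this assay. At this position and on this core, then, phenyl in place of benzyl on the oxygen is not enough on its own to produce a clear change, and no measurement shown here offers an explanation for the result.

Still open, as far as these compounds go, is whether a longer chain on this oxygen, such as phenylethyl, or an amine on the phenyl ring would shift the number. Also open, from the compounds shown here alone, is whether the same swap would read the same way on a core carrying the chloro group of compound 1.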